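Methoxycarbonyl to carboxy: from compound 2 to compound 3

A few compounds are considered here, and "the series" means these few. Any claim that something is new, unique, unknown or untested is made for them only; others in the source may bear on it.

Of the compounds shown here, two have been read so far in a functional assay on SW1573 cells (Homo sapiens) for antiproliferative activity, read by sulforhodamine B assay, with a stated time of 48 h; a higher number here means a weaker inhibitor of growth, a lower number a stronger inhibitor of growth. For compound 1 (`CCCCCCC(C#CC(=O)O)O/C=C/C(=O)OC`) the result is > 100000 nM, which is a limit of the assay and not a number. Going by the values given here, compound 2 (`COC(=O)C#CC(O/C=C/C(=O)OC)C(C)(C)C`) gives 3000 nM, the only actual number, so its standing rests on this single reading.

The next compound is compound 3 (`COC(=O)/C=C/OC(C#CC(=O)O)C(C)(C)C`), related to compound 2 by one change: hydrogen in place of methyl on an oxygen next to a carbonyl group. This is hydrogen in place of methyl on an oxygen next to a carbonyl group, which turns 2-(methoxycarbonyl)ethynyl into 2-carboxyethynyl. Among the compounds with values here, no measured step isolates this change. Within the data shown here, the one available guide is compound 1, which also bears 2-carboxyethynyl and sits at the limit > 100000 nM.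

In this assay a step toward weaker growth inhibition, beyond the usual scatter, is expected. The expected size is a 13-fold higher number from compound 2 to compound 3 (1.12 log units; beyond the scatter). A reading reported only as a limit would not be a surprise. For compound 3 the estimate is 40000 nM, with an expected range of 8000 nM to 100000 nM.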

Compound 3, concentration for 50% growth inhibition: > 100000 nM
Compound 3: a limit, no number (the forecaster's own chance of this, stated with the estimate: 40%); middle value at least 2.5-fold (0.39 log units) from the limit.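

Going by these compounds alone, this is the first measured step for this change, and it is large: hydrogen in place of methyl on an oxygen next to a carbonyl group gives an at least 33-fold higher number from compound 2 to compound 3 (1.52 log units; beyond the scatter), so with tert-butyl in the molecule, the only numeric reading belongs to the compound with 2-(methoxycarbonyl)ethynyl. In this assay, going by these compounds, compound 3 gives > 100000 nM, which is a limit of the assay and not a number, so the printed step gives only the smallest size the data allow, and its true size stays unknown. Compound 1 and compound 3, which both carry 2-carboxyethynyl, cannot be ordered and the step between them cannot be read, since both readings sit at the same limit: the limit of > 100000 nM in this assay, at which 2 of the 3 values shown sit.

Within the data shown here, how a hexyl chain reads alongside 2-(methoxycarbonyl)ethynyl remains open, so the part played by tert-butyl in the one numeric reading cannot yet be separated from that of the methoxycarbonyl group. Also open, on these data alone, is whether an ethoxycarbonyl group or a primary amide in this place would keep a numeric reading in this assay.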